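Notes on dropping the isopropylamino group

This account rests on a few compounds, and the source may have more. Where it says the series, first, only, none or still open, it means among the compounds named here.

For the measured compounds named here, in a functional assay on the whole organism with Mus musculus as the target, in the rotarod test (a higher number here means that more compound is needed for the effect, a lower number that less compound is needed), compound 2 (`CC(C)NCC(=O)NCC(=O)N(C)c1ccc(Cl)cc1C(=O)c1ccccc1Cl`) gives 13 mg/kg, the only actual number so far. Compound 1 (`CN(C(=O)CNC(=O)CN1CCCCC1)c1ccc(Cl)cc1C(=O)c1ccccc1Cl`) gives > 100 mg/kg, which is a limit of the assay. Compound 3 (`CC(=O)NCC(=O)N(C)c1ccc(Cl)cc1C(=O)c1ccccc1Cl`) has hydrogen in place of isopropylamino on a saturated chain carbon bound to a carbonyl carbon. Going by the values given here, only one measured change touches this carbon, the step of an at least 7.6-fold lower number from compound 1 to compound 2 (0.88 log units; beyond the scatter), and it shows that this assay responds to the group there. A move to a higher number is expected, a 3.1-fold higher number from compound 2 to compound 3 (0.49 log units; beyond the scatter). For compound 3 the estimated value is 40 mg/kg, with an expected range of 12 mg/kg to 150 mg/kg.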

Compound 3, dose for half-maximal effect: 58 mg/kg
Compound 3: the middle estimate sits 1.5-fold (0.16 log units) below what was measured, and the stated range covers the measured number.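

With hydrogen on this carbon, this assay shows a 4.5-fold higher number from compound 2 to compound 3 (0.65 log units; beyond the scatter), so the lower number of compound 2 depends on the isopropylamino group, though compound 3 still gives a measured number without it. Hydrogen in place of piperidin-1-yl gives an at least 1.7-fold lower number from compound 1 to compound 3 (0.23 log units; that floor lies within the scatter), which does not order those two groups. Compound 1 gives > 100 mg/kg, which is a limit: the limit of > 100 mg/kg in this assay, at which 1 of the 3 values shown sits.

Open, from the compounds shown here alone, is whether a smaller amine such as methylamino, or a longer chain carrying the isopropylamino group, would match or pass compound 2.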